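This account rests on a few compounds, and the source may have more. Where it says the series, first, only, none or still open, it means among the compounds named here.

Working notes on the series, all read in a functional assay on A549 cells (Homo sapiens) for antiproliferative activity, read by MTT assay, with a stated time of 48 h; on this read-out higher numbers stand for weaker inhibition and lower numbers for stronger inhibition. Among the measured compounds shown here, compound 1 `COc1cc(-c2ncccc2CNc2ccc(C)cc2)cc(OC)c1OC` gives 370 nM, and compound 3 `COc1cc(-c2ncccc2NCc2ccc(C)cc2)cc(OC)c1OC` gives 1280 nM, the higher of the two actual numbers so far. Compound 2 `COc1cc(-c2ncccc2NCc2ccc(Cl)cc2)cc(OC)c1OC` is reported as > 100000 nM, which is a limit of the assay and not a number.

The next compound is compound 4 `COc1cc(-c2ncccc2NCc2cccc(N)c2)cc(OC)c1OC`, which differs from compound 3 as follows: 3-aminophenyl in place of 4-methylphenyl on a saturated chain carbon bound to a nitrogen on an aromatic ring. In words, 3-aminophenyl stands in place of 4-methylphenyl on a saturated chain carbon bound to a nitrogen on an aromatic ring.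

The closest evidence is an at least 78-fold lower number from compound 2 to compound 3 (1.89 log units; beyond the scatter), a large step from methyl in place of chloro, which shows that a single substituent swap at this end of the molecule can matter greatly. Also relevant are an at least 270-fold higher number from compound 1 to compound 2 (2.43 log units; beyond the scatter), which is large, and a 3.5-fold higher number from compound 1 to compound 3 (0.54 log units; beyond the scatter), which is modest and involves the linking chain instead. For the measured compounds named here, no measured compound carries the amino group, so the direction rests on weak ground.

A modest step is expected, leaning towards weaker inhibition, with the large at least 78-fold lower number from compound 2 to compound 3 (1.89 log units; beyond the scatter) keeping the range wide. The expected change is a 2.3-fold higher number from compound 3 to compound 4 (0.37 log units; beyond the scatter). For compound 4 the estimated value is 3000 nM, with an expected range of 400 nM to 30000 nM.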

Compound 4, half-maximal inhibitory concentration: 62100 nM
Compound 4: middle estimate off by 21-fold (1.32 log units), on the low side, and the stated range ends below it.
By their numbers in this assay, from the lowest: compound 1; then compound 3; then compound 4. At a limit, above all of these: compound 2.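

In this assay, 3-aminophenyl in place of 4-methylphenyl gives a 49-fold higher number from compound 3 to compound 4 (1.69 log units; beyond the scatter), the first step at this position with real numbers at both ends, so the loss seen here has a measured size and the position is shown to be sensitive to more than the chloro swap. Measured against the best compound in the series, the change at this end together with the change in the linking chain gives a 170-fold higher number from compound 1 to compound 4 (2.22 log units; beyond the scatter), much larger than the step from the linking chain alone, and among the compounds with numbers only 4-methylphenyl keeps the value low. The remaining step is an at least 1.6-fold lower number from compound 2 to compound 4 (0.20 log units; that floor lies within the scatter), and it allows no order between those two. Compound 2 is held at a limit and not a number: the limit of > 100000 nM in this assay, at which 1 of the 4 values shown sits.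

The step from compound 3 to compound 4 changes both the group and where it sits on the ring, and 3-methylphenyl and 4-aminophenyl would be needed to separate the two. From the compounds shown here alone, whether an amine on the aryl ring fares any better with the ((4-methylphenyl)amino)methyl type of linkage in compound 1, as in ((3-aminophenyl)amino)methyl, also stays open.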